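A few compounds are considered here, and "the series" means these few. Any claim that something is new, unique, unknown or untested is made for them only; others in the source may bear on it.

Measured so far:
- compound 1, `CN(c1ncccc1CNc1nc(Nc2ccccc2)nc2[nH]cc(F)c12)S(C)(=O)=O`: in a functional assay on SMMC-7721 cells (Homo sapiens) for inhibition, read by MTT assay, with a stated time of 48 h (on this read-out lower numbers stand for stronger inhibition and higher numbers for weaker inhibition), compound 1 gives > 100000 nM, a limit of the assay.
- compound 2, `CN(c1ncccc1CNc1nc(Nc2cccc(C#N)c2)nc2[nH]cc(F)c12)S(C)(=O)=O`: in this assay compound 2 gives > 100000 nM, also a limit of the assay.

Compound 2 thus stands at the limit with no number of its own, and both values shown sit there (the limit of > 100000 nM in this assay, at which 2 of the 2 values shown sit). Among the compounds with values here, the one measured step, a step that the two limits leave unreadable from compound 1 to compound 2, is consequently unreadable. Compound 3, `COc1ccc(Nc2nc(NCc3cccnc3N(C)S(C)(=O)=O)c3c(F)c[nH]c3n2)cc1OC`, differs from compound 2 by 3,4-dimethoxyphenyl in place of 3-cyanophenyl on a nitrogen on an aromatic ring. Within the data shown here, no measured step bears on this change, so nothing shows whether this assay would move beyond the scatter. Compound 3 is estimated at 100000 nM (from 20000 nM to 300000 nM), most likely reported again only as a limit, an expected step of a number no higher from compound 2 to compound 3 (the limit leaves the size open).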

Compound 3, half-maximal inhibitory concentration: 54800 nM
For compound 3 the middle estimate is 1.8-fold (0.26 log units) above the measured one, within the range that was stated.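

With 3,4-dimethoxyphenyl on the nitrogen, compound 3 is the only compound shown with a number of its own in this assay, while the other two stop at a limit of the assay: the limit of > 100000 nM in this assay, at which 2 of the 3 values shown sit. Replacing 3-cyanophenyl gives an at least 1.8-fold lower number from compound 2 to compound 3 (0.26 log units; that floor lies within the scatter), and replacing phenyl gives an at least 1.8-fold lower number from compound 1 to compound 3 (0.26 log units; that floor lies within the scatter). On these data alone, the true size of either step therefore stays unknown, but this position can yield a readable value.

As far as these compounds go, it remains open whether a single methoxy group would also give a number. How a hydroxyl or a morpholine on that phenyl ring would read is also unknown.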